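This account rests on a few compounds, and the source may have more. Where it says the series, first, only, none or still open, it means among the compounds named here.

Compound 1 `CC1(C)Oc2ccc(C#N)cc2[C@@H](/N=C(\NC#N)Oc2ccccc2)[C@@H]1O`: > 100000 nM
Compound 2 `CC1(C)Oc2ccc(C#N)cc2[C@@H](/N=C(\NC#N)Nc2cccc(Cl)c2)[C@@H]1O`: 600 nM

Going by the values given here, in a functional assay (aorta) with Rattus norvegicus as the target (a higher number here means a weaker inhibitor, a lower number a stronger inhibitor), compound 2 gives 600 nM, the only exact number so far. Compound 1 stands at > 100000 nM, which is a limit of the assay.

Compound 3 `CC1(C)Oc2ccc(C#N)cc2[C@@H](/N=C(\NC#N)Nc2ccc([N+](=O)[O-])cc2)[C@@H]1O` keeps the core of compound 2 and carries 4-nitrophenyl in place of 3-chlorophenyl on an amine nitrogen.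

Among the compounds with values here, the one measured step, an at least 160-fold lower number from compound 1 to compound 2 (2.22 log units; beyond the scatter), is large, but it exchanges (3-chlorophenyl)amino for phenoxy. The amine nitrogen stays in compound 3, so that step gives no measure of a change of the aryl group. Within the data shown here, no measured step swaps one aryl group for another, so no clear direction can be assigned in this assay. The expected change is small: a 1.2-fold higher number from compound 2 to compound 3 (0.07 log units; within the scatter). For compound 3 the estimated value is 700 nM, with an expected range of 150 nM to 4000 nM.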

Compound 3, half-maximal inhibitory concentration: 300 nM
Estimate against measurement, compound 3: 2.3-fold (0.37 log units) above; the measured number falls inside the stated range.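

In this assay, the exchange of one aryl group for another on the amine nitrogen gives a 2.0-fold lower number from compound 2 to compound 3 (0.30 log units; within the scatter), so 4-nitrophenyl and 3-chlorophenyl cannot be told apart in this series. A second amine-linked aryl group also stands well clear of the phenoxy compound, with an at least 330-fold lower number from compound 1 to compound 3 (2.52 log units; beyond the scatter). The size of that step is only a bound, because compound 1 stands at a limit of the assay: the limit of > 100000 nM in this assay, at which 1 of the 3 values shown sits.

Open, as far as these compounds go, is whether the amine nitrogen accepts a non-aromatic group, such as cyclohexyl or a longer alkyl chain, as well as it accepts these two aryl groups. Also open, from the compounds shown here alone, is how much of the large steps belongs to the nitrogen link and how much to the ring substituents: the phenoxy group carries neither chlorine nor nitro, and plain phenyl on the amine nitrogen would separate the two.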